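The compounds below may be only part of what the source reports. "The series", "measured", "known", "first", "only" and "open" are said of these compounds alone.

Three esters of a shared core have been measured in an ADME assay on a cell-free system (plasma, Homo sapiens) for metabolic stability, with Plasma (Rattus norvegicus) as the target, read by HPLC, at pH 7.4; a higher number here means that the compound lasts longer, a lower number that the compound disappears faster. Compound 1 `CC(=O)Oc1ccccc1C(=O)O[C@H]1CO[C@H]2[C@@H]1OC[C@H]2OC(=O)c1ccccc1O` gives 0.0825 h and stands highest of the three numbers, though only within the scatter of the others. Compound 2 `CC(=O)Oc1ccccc1C(=O)O[C@H]1CO[C@H]2[C@@H]1OC[C@H]2O` gives 0.055 h, and compound 3 `CC(=O)Oc1ccccc1C(=O)O[C@H]1CO[C@H]2[C@@H]1OC[C@H]2OC(=O)c1ccccc1` gives 0.055 h. The step of a 1.5-fold lower number from compound 1 to compound 2 (0.18 log units; within the scatter) and the step of a 1.5-fold lower number from compound 1 to compound 3 (0.18 log units; within the scatter) both stay within the scatter, as does the step of no change at the digits printed from compound 2 to compound 3 (within the scatter).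

Compound 4 `CC(=O)Oc1ccccc1C(=O)O[C@H]1CO[C@H]2[C@@H]1OC[C@H]2OC(=O)c1ccc(C#N)cc1` is the next candidate. Compared with compound 1 the change is 4-cyanophenyl in place of 2-hydroxyphenyl on a carbonyl carbon. Going by the values given here, the steps that bear on it are the removal of the hydroxy from compound 1 to compound 3, and the exchange of the whole (2-hydroxyphenyl)carbonyl for hydrogen from compound 1 to compound 2; neither moved the half-life beyond the scatter. For compound 4 the expected step is therefore a 1.4-fold lower number from compound 1 to compound 4 (0.14 log units; within the scatter), no real change. The estimated value for compound 4 is 0.06 h, with a range from 0.03 h to 0.12 h.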

Compound 4, half-life: 0.0888 h
Beside the measured number, compound 4's estimate is 1.5-fold (0.17 log units) below it; the range from low to high includes it.
By their numbers in this assay, from the lowest: compounds 2, 3, 1 and 4 (each within the scatter of the next).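

In this assay the place on the carbonyl carbon also accepts a nitrile-bearing ring: 4-cyanophenyl in place of 2-hydroxyphenyl gives a 1.1-fold higher number from compound 1 to compound 4 (0.03 log units; within the scatter) and cyano in place of hydrogen on the aromatic carbon gives a 1.6-fold higher number from compound 3 to compound 4 (0.21 log units; within the scatter) without leaving the usual spread of repeat measurements. Going by these compounds alone, putting the whole (4-cyanophenyl)carbonyl in place of hydrogen gives a 1.6-fold higher number from compound 2 to compound 4 (0.21 log units; within the scatter) and so completes a set of four compounds in which no step at this place goes beyond the scatter, whether the ring carries hydroxy, cyano or neither, or is absent. Nothing measured here speaks to what lies behind this flat picture.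

Still open, as far as these compounds go, is whether an amine or a carboxylic acid on the ring, or a longer chain in place of the ring, would move the half-life beyond the scatter. Also open, from the compounds shown here alone, is whether a change to the other ester, which is the same in all four compounds, would do so.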